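The compounds below may be only part of what the source reports. "The series", "measured", "known", "first", "only" and "open" are said of these compounds alone.

Working notes on the series. Compound 1 `Cc1cc(C(=O)O)nn1Cc1cc(Br)ccc1OCc1ccccc1Cl` gives 28.8 nM in a functional assay on CHO-K1 cells for antagonist activity at prostaglandin E2 receptor EP1 subtype (Homo sapiens), read by FLIPR; a lower number here means a stronger inhibitor, a higher number a weaker inhibitor. Compound 2 `COc1ccccc1COc1ccc(Br)cc1Cn1nc(C(=O)O)cc1C` gives 69.2 nM in this assay, and compound 3 `Cc1cc(C(=O)O)nn1Cc1cc(Br)ccc1OCc1cccc(Br)c1` gives 129 nM. Compound 3 thus stands at the highest of the three numbers: the step of a 1.9-fold higher number from compound 2 to compound 3 (0.27 log units; within the scatter) lies within the scatter, whereas a 4.5-fold higher number from compound 1 to compound 3 (0.65 log units; beyond the scatter) lies beyond it, as does a 2.4-fold higher number from compound 1 to compound 2 (0.38 log units; beyond the scatter). Compound 4 `Cc1cc(C(=O)O)nn1Cc1cc(Br)ccc1OCc1cccc(Cl)c1` is the next member and differs from compound 3 in one place: chloro in place of bromo on an aromatic carbon. Going by the values given here, none of the measured steps exchanges one halogen for another on the benzyl group; two of them replace the whole benzyl group and the third replaces chloro with methoxy, so none bears directly on the present change. Among the compounds with values here, with no measured pair pointing either way, no step beyond the scatter is expected from this exchange. The expected step is a 1.0-fold higher number from compound 3 to compound 4 (0.00 log units; within the scatter). For compound 4 the estimate in this assay is 130 nM, with a range from 50 nM to 340 nM.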

Compound 4, inhibition constant: 427 nM
Beside the measured number, compound 4's estimate is 3.3-fold (0.52 log units) below it; measured number outside the range, above it.
By their numbers in this assay, from the lowest: compound 1; then compounds 2 and 3 (each within the scatter of the next); then compound 4.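

In this assay, going by these compounds alone, the two halogens are not interchangeable on this aromatic carbon, meta to a large group: chloro in place of bromo gives a 3.3-fold higher number from compound 3 to compound 4 (0.52 log units; beyond the scatter) and is the first measured step on the benzyl group that changes the halogen alone. With chloro kept, 3-chlorophenyl in place of 2-chlorophenyl gives a 15-fold higher number from compound 1 to compound 4 (1.17 log units; beyond the scatter) and is the largest step in the set, while 3-chlorophenyl in place of 2-methoxyphenyl gives a 6.2-fold higher number from compound 2 to compound 4 (0.79 log units; beyond the scatter) and leaves compound 4 the weakest of the four. Nothing measured here accounts for the size of these steps.

Open, as far as these compounds go, is how fluoro, methyl or nitrile would read on the same aromatic carbon. Also open, from the compounds shown here alone, is whether the halogen exchange would give a step of similar size on the 2-chlorophenyl group of compound 1.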